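The source may report more compounds than this note shows. Statements on the series, on what has been measured and on what is new or still open speak of the compounds shown alone.

Measured so far:
- compound 1, `Nc1scc(CN2CCN(c3ccccc3C(F)(F)F)CC2)c1C(=O)c1ccc(Cl)cc1`, 0%
- compound 2, `Nc1scc(CN2CCN(C3CCCCCC3)CC2)c1C(=O)c1ccc(Cl)cc1`, 0%

In an assay on CHO cells for displacement of a labelled ligand from adenosine receptor A1 (Homo sapiens), read by scintillation counting, with a stated time of 120 min, tested at 10 uM (on this read-out higher numbers stand for more inhibition at the one concentration tested (going by the name of the read-out) and lower numbers for less inhibition), compound 1 gives 0% and compound 2 gives 0%. Going by the values given here, the one measured step, no change at the digits printed from compound 1 to compound 2 (within the scatter), shows that swapping an aromatic group for a saturated ring on the ring nitrogen leaves the read-out flat at the floor of the assay. Compound 2 therefore stands level with compound 1, both showing no measurable displacement at the concentration tested.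

Compound 3, `Nc1scc(CN2CCN(c3cc(F)ccc3F)CC2)c1C(=O)c1ccc(Cl)cc1`, carries the change (2,5-difluorophenyl in place of cycloheptyl on an amine nitrogen in a ring). Among the compounds with values here, this is the reverse sense of the only step on record, which moved an aromatic group off the same nitrogen without effect; that step measured no change at the digits printed from compound 1 to compound 2 (within the scatter). Putting a fluorinated aromatic group back on is thus expected to produce a number 2 percentage points higher from compound 2 to compound 3 (within the scatter), no movement beyond the scatter. Compound 3 is estimated at 2%, range -10% to 15%.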

Compound 3, a percentage reported as inhibition, at one concentration (the size of the read-out at that concentration, not a potency): 1%
Compound 3: middle estimate off by 1 percentage points, on the high side; measured number inside the range.
By their numbers in this assay, from the lowest: compounds 1, 2 and 3 (each within the scatter of the next).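

In this assay, a number 1 percentage points higher from compound 2 to compound 3 (within the scatter), so returning to an aromatic group on the amine nitrogen in a ring does not separate the aromatic and saturated substituents. Exchanging one fluorinated aromatic group for another gives a number 1 percentage points higher from compound 1 to compound 3 (within the scatter), so 2,5-difluorophenyl and 2-(trifluoromethyl)phenyl are also not separated, and a second substitution pattern on the phenyl ring now joins cycloheptyl in reading alike at this position. No supporting measurement is available to explain this flat result.

Going by these compounds, whether a methyl group, a benzyl group or a chain ending in a carboxylic acid on this nitrogen would move the read-out beyond the scatter remains open. Also open, on these data alone, is whether changes elsewhere on the shared core would do so.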